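Two Amides Measured, a Difluoromethylpiperidine Amide Still Unknown

This account rests on a few compounds, and the source may have more. Where it says the series, first, only, none or still open, it means among the compounds named here.

Compound 1, `CCN(CC)S(=O)(=O)c1ccc(S(=O)(=O)N2CCC[C@@H](C(=O)N[C@@H]3CCOC3)C2)cc1`, gives 2270 nM in a functional assay on BXPC-3 cells (Homo sapiens) for inhibition, read by MTT assay, with a stated time of 7 days; a higher number here means a weaker inhibitor, a lower number a stronger inhibitor.
Compound 2, `CCN(CC)S(=O)(=O)c1ccc(S(=O)(=O)N2CCC[C@@H](C(=O)N3CCS(=O)(=O)CC3)C2)cc1`, gives 4430 nM in this assay.

Compound 2 and compound 1 lie within the scatter of each other, as a 2.0-fold higher number from compound 1 to compound 2 (0.29 log units; within the scatter) shows. Compound 3, `CCN(CC)S(=O)(=O)c1ccc(S(=O)(=O)N2CCC[C@@H](C(=O)N3CCC(C(F)F)CC3)C2)cc1`, differs from compound 2 by 4-(difluoromethyl)piperidin-1-yl in place of 1,1-dioxothiomorpholin-4-yl on a carbonyl carbon. Among the compounds with values here, the only step bearing on this place is a 2.0-fold higher number from compound 1 to compound 2 (0.29 log units; within the scatter), which exchanged a group on the same carbonyl carbon and stayed within the scatter, so no step beyond the scatter is expected here either, and compound 3 is estimated at 3500 nM, between 1000 nM and 12000 nM, with an expected step of a 1.3-fold lower number from compound 2 to compound 3 (0.10 log units; within the scatter).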

Compound 3, half-maximal inhibitory concentration: 450 nM
Estimate against measurement, compound 3: 7.8-fold (0.89 log units) above, and the stated range ends above it.
By their numbers in this assay, from the lowest: compound 3; then compounds 1 and 2 (each within the scatter of the next).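

In this assay, this carbonyl carbon proves sensitive to its group, a change the earlier pair could not show: 4-(difluoromethyl)piperidin-1-yl gives a 9.8-fold lower number from compound 2 to compound 3 (0.99 log units; beyond the scatter) and a 5.0-fold lower number from compound 1 to compound 3 (0.70 log units; beyond the scatter). Both steps lie beyond the scatter, so the new group separates from both earlier amides. No measurement shown explains this gain.

On these data alone, it remains open whether the gain belongs to the difluoromethyl group or to the piperidine ring. A plain piperidin-1-yl or a 4-(trifluoromethyl)piperidin-1-yl on the same carbonyl carbon would help separate the two.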